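Methoxy to Methylsulfanyl on a Shared Nucleoside Core

The compounds below may be only part of what the source reports. "The series", "measured", "known", "first", "only" and "open" are said of these compounds alone.

Compound 1 `COc1ncnc2c1c(-c1ccsc1)cn2[C@@H]1O[C@H](CO)[C@@H](O)[C@H]1O` — in a functional assay on HeLa S3 cells (Homo sapiens) for antiproliferative activity, read by XTT assay, with a stated time of 72 h (a higher number here means a weaker inhibitor, a lower number a stronger inhibitor), compound 1 gives 3350 nM.
Compound 2 `COc1ncnc2c1c(-c1cccs1)cn2[C@@H]1O[C@H](CO)[C@@H](O)[C@H]1O` — in this assay compound 2 gives 1760 nM.
Compound 3 `COc1ncnc2c1c(-c1ccccc1)cn2[C@@H]1O[C@H](CO)[C@@H](O)[C@H]1O` — in this assay compound 3 gives > 20000 nM, which is a limit of the assay and not a number (the limit of > 20000 nM in this assay, at which 1 of the 3 values shown sits).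

Compound 2 stands at the low end of the two numbers shown, with compound 1 a step of a 1.9-fold lower number from compound 1 to compound 2 (0.28 log units; within the scatter) apart, a gap within the scatter. Compound 4 `CSc1ncnc2c1c(-c1cccs1)cn2[C@@H]1O[C@H](CO)[C@@H](O)[C@H]1O` differs from compound 2 by methylsulfanyl in place of methoxy on an aromatic carbon. Among the compounds with values here, none of the measured steps touches this place: a 1.9-fold lower number from compound 1 to compound 2 (0.28 log units; within the scatter), an at least 5.9-fold higher number from compound 1 to compound 3 (0.77 log units; beyond the scatter) and an at least 11-fold higher number from compound 2 to compound 3 (1.05 log units; beyond the scatter) all exchange the aryl ring on the shared core, so none bears on the exchange of methoxy for methylsulfanyl. Within the data shown here, with no guiding step, compound 4 is expected to show a step of a 1.0-fold higher number from compound 2 to compound 4 (0.01 log units; within the scatter) in this assay, not beyond the scatter. The estimated value for compound 4 is 1800 nM, with a range from 600 nM to 5500 nM.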

Compound 4, half-maximal inhibitory concentration: 1960 nM
The estimate for compound 4 lay 1.1-fold (0.04 log units) below the measured number; the measured number falls inside the stated range.
By their numbers in this assay, from the lowest: compounds 2, 4 and 1 (each within the scatter of the next). At a limit, above all of these: compound 3.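

In this assay, placing methylsulfanyl instead of methoxy on the aromatic carbon next to the ring nitrogen gives a 1.1-fold higher number from compound 2 to compound 4 (0.05 log units; within the scatter) and leaves the two compounds indistinguishable. The earlier steps shown here all exchanged the aryl ring; this one shows that, with thiophen-2-yl held fixed, methoxy at this position can give way to methylsulfanyl without a step beyond the scatter.

Going by these compounds, whether this holds with thiophen-3-yl or phenyl on the shared core remains open, as does what an amine or a longer chain at this place would give. Nothing shown here bears on the reason for this result.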